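The source may hold more compounds than are shown below. What is called first, only, known or untested is meant among the compounds shown, and "the series" means these compounds.

Measured so far:
- Compound 1 `C=C(C)C(=O)NC(=O)NC1=CS(=O)(=O)O[C@@]12[C@@H](CO[Si](C)(C)C(C)(C)C)O[C@@H](n1cc(C)c(=O)n(C)c1=O)[C@@H]2O[Si](C)(C)C(C)(C)C` gives 1200 nM in a functional assay on HEL cells (Homo sapiens); on this read-out lower numbers stand for higher toxicity in this test and higher numbers for lower toxicity in this test.
- Compound 2 `COC(=O)CC(=O)NC1=CS(=O)(=O)O[C@@]12[C@@H](CO[Si](C)(C)C(C)(C)C)O[C@@H](n1cc(C)c(=O)n(C)c1=O)[C@@H]2O[Si](C)(C)C(C)(C)C` gives 29000 nM in this assay.

Going by the values given here, compound 2 has the higher of the two numbers, meaning it is the less toxic of the pair in this test; its only neighbour is compound 1, separated by the step of a 24-fold higher number from compound 1 to compound 2 (1.38 log units; beyond the scatter), a change of the group on the carbonyl carbon attached to the amine nitrogen.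

Compound 3 `Cc1cn([C@@H]2O[C@H](CO[Si](C)(C)C(C)(C)C)[C@@]3(OS(=O)(=O)C=C3NCCC(=O)OCc3ccccc3)[C@H]2O[Si](C)(C)C(C)(C)C)c(=O)n(C)c1=O` arises from compound 2 by a different kind of change: 2-(benzyloxycarbonyl)ethyl in place of ((methoxycarbonyl)methyl)carbonyl on an amine nitrogen. Here the whole ((methoxycarbonyl)methyl)carbonyl group, carbonyl included, gives way to a 2-(benzyloxycarbonyl)ethyl chain that is not a carbonyl at all, so the amine nitrogen now carries a plain chain rather than a carbonyl.

Among the compounds with values here, the single measured step bears on this only loosely: it shows that the group on this nitrogen can move the number a great deal, as a 24-fold higher number from compound 1 to compound 2 (1.38 log units; beyond the scatter) did, but it swapped one carbonyl-bearing group for another and says nothing about removing the carbonyl. Within the data shown here, with that step as the only guide, a move of uncertain direction is expected, most likely toward a somewhat lower number, and the estimate for compound 3 is 8000 nM within 1500 nM to 40000 nM, corresponding to an expected step of a 3.6-fold lower number from compound 2 to compound 3 (0.56 log units; beyond the scatter).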

Compound 3, half-maximal cytotoxic concentration: 200000 nM
The estimate for compound 3 lay 25-fold (1.40 log units) below the measured number; measured number outside the range, above it.
By their numbers in this assay, from the lowest: compound 1; then compound 2; then compound 3.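

In this assay, going by these compounds alone, the amine nitrogen can lose its carbonyl altogether: with 2-(benzyloxycarbonyl)ethyl in place of ((methoxycarbonyl)methyl)carbonyl, the step is a 6.9-fold higher number from compound 2 to compound 3 (0.84 log units; beyond the scatter) and points toward lower toxicity in this test, which the single earlier step between two carbonyl-bearing groups could not show. The wider step a 170-fold higher number from compound 1 to compound 3 (2.22 log units; beyond the scatter) places 2-(benzyloxycarbonyl)ethyl at the low-toxicity end of the three groups seen on this nitrogen, so the span across this one position is now larger than the earlier step alone suggested. No measurement at hand accounts for this rise.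

The change from compound 2 to compound 3 removes the carbonyl on the nitrogen and brings in a six-membered aromatic ring at the same time, so the compounds shown cannot say which of these parts goes with the higher number. From the compounds shown here alone, a 2-(methoxycarbonyl)ethyl chain, which has no aromatic ring, or a chain ending in a carboxylic acid on the same nitrogen would help separate the two, and how either reads in this assay remains open.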